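The compounds below may be only part of what the source reports. "The series", "measured", "known", "first", "only" and "open" are said of these compounds alone.

Compound 1 `C[Se]c1nc(N)c2ccccc2n1` gives 59000 nM in an ADME assay on 184B5 cells (Homo sapiens) for cytotoxicity, read by MTT assay, with a stated time of 72 h; on this read-out lower numbers stand for stronger inhibition of growth and higher numbers for weaker inhibition of growth.
Compound 2 `COc1ccc(CNc2nc([SeH])nc3ccccc23)cc1` gives only a limit, > 100000 nM.
Compound 3 `CSc1nc(NCc2ccccc2)c2ccccc2n1` also gives only a limit, > 100000 nM.

Within the data shown here, compound 1 thus stands alone as the only measured number, set against (the limit of > 100000 nM in this assay, at which 2 of the 3 values shown sit). It is a weak inhibitor of growth, and nothing among the three shows how the groups on selenium or sulfur shape that weakness.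

Compound 4 `Nc1nc([SeH])nc2ccccc12` differs from compound 1 by hydrogen in place of methyl on a selenium. Among the measured compounds shown here, no measured pair shows this change alone. A small step toward weaker inhibition is expected, a 1.4-fold higher number from compound 1 to compound 4 (0.13 log units; within the scatter), possibly within the scatter. Compound 4 is estimated at 80000 nM, between 30000 nM and 200000 nM, with a real chance that only a limit is reported.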

Compound 4, concentration for total growth inhibition: 36700 nM
Compound 4: the middle estimate sits 2.2-fold (0.34 log units) above what was measured, within the range that was stated.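

Among these compounds, this is the first step measured at this position, and in this assay hydrogen in place of methyl on a selenium makes no clear difference: a 1.6-fold lower number from compound 1 to compound 4 (0.21 log units; within the scatter). The methyl group on the selenium is therefore not needed for the weak growth inhibition seen with compound 1. Compound 1 and compound 4 both give actual numbers rather than a limit, which cannot be taken for granted in this series: the limit of > 100000 nM in this assay, at which 2 of the 4 values shown sit.

On these data alone, whether an ethyl group or a longer chain on the selenium would move the number beyond the scatter remains open. So does whether a carboxylic acid at that place would leave it unchanged.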